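Allyl-substituted bis-arylidene series: cytotoxicity on a leukaemia cell line

This account rests on a few compounds, and the source may have more. Where it says the series, first, only, none or still open, it means among the compounds named here.

Measured compounds
- compound 1 `C=CCn1c(=O)/c(=C\c2cccc(Br)c2)[nH]c(=O)/c1=C\c1cccc(Br)c1`: "not active" (no number reported)
- compound 2 `C=CCn1c(=O)/c(=C\c2ccccc2F)[nH]c(=O)/c1=C\c1ccccc1OC`: 20000 nM
- compound 3 `COc1ccccc1/C=c1/[nH]c(=O)/c(=C\c2nc[nH]c2C(C)(C)C)[nH]c1=O`: "not determined" (no result reported)

In a functional assay on MOLT-4 cells (Homo sapiens) for cytotoxicity, read by CCK-8 assay, with a stated time of 72 h (on this read-out higher numbers stand for weaker inhibition and lower numbers for stronger inhibition), compound 2 gives 20000 nM. Among the compounds with values here, this is the only number in the set: compound 1 is reported as "not active" (no number reported), and for compound 3 the result is "not determined" (no result reported), so compound 2 cannot be ranked against either of them and only shows weak inhibition on its own.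

Compound 4 `C=CCn1c(=O)/c(=C\c2cccc(Cl)c2Cl)[nH]c(=O)/c1=C\c1ccccc1OC` is the next compound to be measured in this assay. It differs from compound 2 in one place: 2,3-dichlorophenyl in place of 2-fluorophenyl on a double-bonded chain carbon bound to an aromatic carbon. Within the data shown here, no step between measured compounds is available that would show what such a change does; the only neighbour with halogen on both aryl rings, compound 1, returned no number.

With compound 2 already weak, the step of a 1.1-fold lower number from compound 2 to compound 4 (0.05 log units; within the scatter) is expected to stay within the usual scatter, with no clear direction. Compound 4 is therefore estimated at 18000 nM, with a plausible range from 6000 nM to 50000 nM, and a real chance that only a limit is reported.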

Compound 4, half-maximal inhibitory concentration: 1200 nM
Compound 4: middle estimate off by 15-fold (1.18 log units), on the high side; measured number below the stated range.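

In this assay, the aryl group on a double-bonded chain carbon bound to an aromatic carbon proves sensitive to substitution: 2,3-dichlorophenyl in place of 2-fluorophenyl gives a 17-fold lower number from compound 2 to compound 4 (1.22 log units; beyond the scatter). Within the data shown here, this is the first step that can be read, and it lies beyond the scatter, which a single number for compound 2 could not show. No measurement available here accounts for the size of this step.

A single step cannot separate the contribution of each chlorine or show whether replacing fluorine or adding a second halogen matters more; 2-chlorophenyl and 3-chlorophenyl would address this. On these data alone, whether the step holds with a longer chain or a carboxylic acid in place of the allyl group also stays open.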